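The source may hold more compounds than are shown below. What is called first, only, known or untested is meant among the compounds shown, and "the series" means these compounds.

Going by the values given here, in a functional assay on HepG2 cells (Homo sapiens) for inhibition, read by MTT assay, with a stated time of 72 h (a higher number here means a weaker inhibitor, a lower number a stronger inhibitor), compound 1 `Cc1nc(N(C)C(=O)NC(=O)c2c(F)cccc2F)sc1C(=O)N/N=C/c1ccccc1` gives 54.3 ug/mL and compound 2 `COc1ccc(/C=N/NC(=O)c2sc(N(C)C(=O)NC(=O)c3c(F)cccc3F)nc2C)cc1` gives 22.7 ug/mL, the lowest of the two numbers so far. Among the compounds with values here, the only measured step, a 2.4-fold lower number from compound 1 to compound 2 (0.38 log units; beyond the scatter), is the sole change on that aromatic ring. Compound 3 `Cc1nc(N(C)C(=O)NC(=O)c2c(F)cccc2F)sc1C(=O)N/N=C/c1ccc(C(F)(F)F)cc1` carries trifluoromethyl in place of methoxy on an aromatic carbon. Within the data shown here, no measured step exchanges methoxy for trifluoromethyl, so nothing shows whether the number moves in either direction. For compound 3 the step from compound 2 is expected to stay within the scatter, a 1.1-fold higher number from compound 2 to compound 3 (0.04 log units; within the scatter). The value of compound 3 in this assay is estimated at 25 ug/mL, with a range from 10 ug/mL to 60 ug/mL.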

Compound 3, half-maximal inhibitory concentration: > 100 ug/mL
Compound 3 ended at the assay's limit; the forecaster's own chance of this, stated with the estimate: 5%; middle value at least 4.0-fold (0.60 log units) away from the limit.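

In this assay compound 3 stands at a limit and not at a number: the limit of > 100 ug/mL in this assay, at which 1 of the 3 values shown sits. On this aromatic carbon, para to a large group, trifluoromethyl in place of methoxy gives an at least 4.4-fold higher number from compound 2 to compound 3 (0.64 log units; beyond the scatter), so this position responds strongly to the choice of group. With trifluoromethyl in place of hydrogen the reading is an at least 1.8-fold higher number from compound 1 to compound 3 (0.26 log units; that floor lies within the scatter), so only methoxy is shown to differ from hydrogen beyond the scatter.

From the compounds shown here alone, how far the true value of compound 3 lies past the limit stays open. So does how an amine or a carboxylic acid at this position would read.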